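The source may hold more compounds than are shown below. What is called first, only, known or untested is meant among the compounds shown, and "the series" means these compounds.

Series around the shared core of compound 1 `CC1CCN(c2c(S(=O)(=O)c3ccccc3)cnc3ccccc23)CC1`, which in an assay on isolated protein for displacement of a labelled ligand from metabotropic glutamate receptor 5 (Homo sapiens), with a stated time of 60 min, tested at 1 uM (on this read-out higher numbers stand for more inhibition at the one concentration tested (going by the name of the read-out) and lower numbers for less inhibition), gives 89.2%. Compound 2 `CC1CCN(c2c(S(=O)(=O)c3ccccc3)cnc3c(F)cccc23)CC1` gives 13% and compound 3 `CC1CCN(c2c(S(=O)(=O)c3ccccc3)cnc3ccc(F)cc23)CC1` gives 40%. Compound 2 stands lowest of the three: the step of a number 76.2 percentage points lower from compound 1 to compound 2 (beyond the scatter) and the step of a number 49.2 percentage points lower from compound 1 to compound 3 (beyond the scatter) are both beyond the scatter. Compound 4 `CC1CCN(c2c(S(=O)(=O)c3ccc(F)c(Cl)c3)cnc3c(F)cccc23)CC1` differs from compound 2 by 3-chloro-4-fluorophenyl in place of phenyl on a sulfonyl sulfur. Among the compounds with values here, neither measured step bears on this change: both concern fluoro in place of hydrogen on an aromatic carbon of the core, and no measured pair varies the group on the sulfonyl sulfur. With nothing to anchor a direction, no step beyond the scatter is expected, so a number 2 percentage points higher from compound 2 to compound 4 (within the scatter). Compound 4 is estimated at 15%, between 0% and 45%.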

Compound 4, a percentage reported as inhibition, at one concentration (the size of the read-out at that concentration, not a potency): 95%
Compound 4: the middle estimate sits 80 percentage points below what was measured; the measured number lies above the stated range.
By their numbers in this assay, from the lowest: compound 2; then compound 3; then compounds 1 and 4 (each within the scatter of the next).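

On a sulfonyl sulfur, 3-chloro-4-fluorophenyl in place of phenyl gives a number 82 percentage points higher from compound 2 to compound 4 (beyond the scatter) in this assay. This is the only listed step upward, and it shows that the group on the sulfonyl sulfur can move the number by a large amount. The low number of compound 2 is therefore not set by its fluoro on the core alone. No measurement available here accounts for this step.

Still open, from the compounds shown here alone, is how the chloro and the fluoro of the new group each contribute to the step. Also open, going by these compounds, is whether a methoxy group or an amine on that ring would hold the number.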